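Longer phosphate alkyl chain on the pyrrolidine dithiocarbamate

The source may hold more compounds than are shown below. What is called first, only, known or untested is meant among the compounds shown, and "the series" means these compounds.

Measured so far:
compound 1, `CCCOP(=O)(O)OCCSC(=S)N1CCCC1`: > 100000 nM
compound 2, `CCCOP(=O)(O)OCCSC(=S)N1CCCCCC1`: 86100 nM

In a functional assay on DU-145 cells (Homo sapiens) for inhibition, read by MTT assay, with stated times of 18 h and 4 h (on this read-out higher numbers stand for weaker inhibition and lower numbers for stronger inhibition), compound 1 gives > 100000 nM, which is a limit of the assay and not a number. It sits at the limit of > 100000 nM in this assay, at which 1 of the 2 values shown sits. In this assay, among the compounds with values here, compound 2 gives 86100 nM, a number rather than a limit; no step between compound 1 and compound 2 is counted here, and their values show only that much.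

Compound 3, `CCCCCCOP(=O)(O)OCCSC(=S)N1CCCC1`, differs from compound 1 by propyl in place of hydrogen on a saturated chain carbon, three bonds along the chain from an oxygen on an unsaturated carbon. Within the data shown here, no measured step covers a change of this kind, so the expected step from compound 1 to compound 3 is small, towards stronger inhibition, an at least 1.6-fold lower number from compound 1 to compound 3 (0.22 log units; that floor lies within the scatter). Compound 3 is estimated at 60000 nM, with a range from 20000 nM to 150000 nM.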

Compound 3, half-maximal inhibitory concentration: > 100000 nM
Compound 3: only a limit was reported (the forecaster's own chance of this, stated with the estimate: 40%); at least 1.6-fold (0.22 log units) between middle value and limit.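

In this assay compound 3 gives > 100000 nM, a limit and not a number. Within the data shown here, compound 1 also stands at a limit, so no step to compound 3 can be read. The compounds shown leave open whether propyl to hexyl changes inhibition at all.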